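From sulfamoyl to hydroxymethyl on the shared core

This account rests on a few compounds, and the source may have more. Where it says the series, first, only, none or still open, it means among the compounds named here.

Compound 1 (`Cc1cc(N)cc(C)c1Oc1cc(Nc2ccc(C#N)cc2)c(N)cc1C(F)(F)F`): 15800 nM
Compound 2 (`Cc1cc(/C=C/C#N)cc(C)c1Oc1cc(Nc2ccc(C#N)cc2)c(N)cc1S(N)(=O)=O`): > 21800 nM (a limit)
Compound 3 (`Cc1cc(CCC#N)cc(C)c1Oc1cc(Nc2ccc(C#N)cc2)c(N)cc1N`): > 25000 nM (a limit)

All three values come from an ADME assay on TZM cells (Homo sapiens) for cytotoxicity, read by XTT assay, with a stated time of 4 days (on this read-out lower numbers stand for higher toxicity in this test and higher numbers for lower toxicity in this test), and no pair of these compounds differs in one place only. Compound 2 has no number in this test, only a limit (> 21800 nM). Compound 3 likewise has only a limit (> 25000 nM). Compound 1 alone gives a number (15800 nM).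

The next compound is compound 4 (`Cc1cc(/C=C/C#N)cc(C)c1Oc1cc(Nc2ccc(C#N)cc2)c(N)cc1CO`), which differs from compound 2 by hydroxymethyl in place of sulfamoyl on an aromatic carbon. For the measured compounds named here, no measured step shows what such a change does. The expectation therefore rests on compound 1 (15800 nM), and no step beyond the scatter is expected in this assay in either direction. The estimated step of an at least 1.2-fold lower number from compound 2 to compound 4 (0.08 log units; that floor lies within the scatter) stays small. In this assay compound 4 is estimated at 18000 nM with a range from 6000 nM to 40000 nM as the expected bounds.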

Compound 4, half-maximal cytotoxic concentration: 16300 nM
Compound 4: the middle estimate sits 1.1-fold (0.04 log units) above what was measured; low and high end bracket the measured number.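

In this assay, for the compounds shown here, hydroxymethyl on this aromatic carbon gives the first step on the shared core that can be read at all: an at least 1.3-fold lower number from compound 2 to compound 4 (0.12 log units; that floor lies within the scatter). Compound 4 carries a measured number at this position, whereas compound 2 offers only a limit, so the change from sulfamoyl can be bounded on one side and no more. The step stands only as a floor because compound 2 has a limit and not a number: the limit of > 21800 nM in this assay, at which 1 of the 4 values shown sits.

The compounds shown leave open how large the step really is, and whether a carboxylic acid, an amine or a longer chain on this aromatic carbon would give a lower or higher number in this assay. Compound 1 and compound 3 carry other groups here but differ from compound 4 in more than one place, so they do not settle this.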